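The source may hold more compounds than are shown below. What is called first, only, known or untested is meant among the compounds shown, and "the series" means these compounds.

Measured compounds:
Compound 1 `CNc1cc(Oc2c(OC)cc3cc(C#N)ccc3c2OC)nc(Nc2ccc(C#N)cc2)n1` gives 239000 nM in an ADME assay on MT4 cells (Homo sapiens) for cytotoxicity, read by MTT assay, with a stated time of 5 days; a higher number here means that more compound is tolerated, a lower number that less compound is tolerated.
Compound 2 `CCCCCNc1cc(Oc2c(OC)cc3cc(C#N)ccc3c2OC)nc(Nc2ccc(C#N)cc2)n1` gives > 125000 nM in this assay, which is a limit of the assay and not a number.

In this assay, going by the values given here, compound 1 stands as the only value given as a number; the one other value shown is a limit. Compound 3 `COc1cc2cc(C#N)ccc2c(OC)c1Oc1cc(NCC(C)(C)C)nc(Nc2ccc(C#N)cc2)n1` has not yet been measured in this assay. It differs from compound 1 in one place: tert-butyl in place of hydrogen on a saturated chain carbon bound to a nitrogen on an aromatic ring. Among the compounds with values here, the one measured step that bears on this change is a step that the limit leaves unreadable from compound 1 to compound 2, in which a chain also replaces hydrogen on a saturated chain carbon bound to a nitrogen on an aromatic ring; its size cannot be read since compound 2 sits at the limit of > 125000 nM in this assay, at which 1 of the 2 values shown sits. The measured data thus give no readable step for adding a chain at this position, and both values shown lie in a region where much compound is tolerated. Compound 3 is therefore expected to stay in that same region, with an expected step of a 1.2-fold lower number from compound 1 to compound 3 (0.08 log units; within the scatter) no larger than the usual scatter. The estimate for compound 3 in this assay is 200000 nM, with a range from 100000 nM to 400000 nM, and a fair chance that only a limit is reported.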

Compound 3, half-maximal cytotoxic concentration: > 125000 nM
Compound 3: a limit, no number; the forecaster's own chance of this, stated with the estimate: 55%; the middle value lies beyond the limit too.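

In this assay the steps from compound 1 to compound 3 and from compound 2 to compound 3 cannot be read, as compound 2 and compound 3 are each reported only as a limit and not a number: the limit of > 125000 nM in this assay, at which 2 of the 3 values shown sit. The compounds shown leave open how far the values of compound 2 and compound 3 lie from that of compound 1, and whether the longer chains change the amount tolerated at all.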